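Nitro for cyano on the shared thiohydantoin-type core

The source may report more compounds than this note shows. Statements on the series, on what has been measured and on what is new or still open speak of the compounds shown alone.

Among the compounds with values here, compound 1 `CC(O)(CSc1cccc(C(F)(F)F)c1)C(=O)Nc1cc(C(F)(F)F)cc(C(F)(F)F)c1` is the only member of this set with a number: in a functional assay on LNCaP cells (Homo sapiens) for antiproliferative activity, read by fluorescence and propidium iodide staining, with a stated time of 96 h (on this read-out lower numbers stand for stronger inhibition and higher numbers for weaker inhibition), compound 1 gives 8750 nM. Within the data shown here, compound 2 `CC1(C)C(=O)N(c2ccc(C#N)cc2C(F)(F)F)C(=S)N1c1cc(C(F)(F)F)cc(C(F)(F)F)c1` carries the same bis(trifluoromethyl)phenyl fragment on a different core; for compound 2 the record in this assay reads "nd(insoluble)" (no result reported), so no number stands for it and no step from compound 1 can be computed. Compound 3 `CC1(C)C(=O)N(c2ccc([N+](=O)[O-])cc2C(F)(F)F)C(=S)N1c1cc(C(F)(F)F)cc(C(F)(F)F)c1` differs from compound 2 in one place: nitro in place of cyano on an aromatic carbon. Among the measured compounds shown here, with compound 2 lacking a value, no step size or direction in this assay can be stated between compound 2 and compound 3; the only anchor is the value of compound 1, which sits on a different core, and the change itself gives no basis for predicting a move beyond the scatter. Compound 3 is therefore expected, with wide uncertainty and a real chance of no number being returned, to give about 2000 nM, within a range from 300 nM to 15000 nM.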

Compound 3, half-maximal inhibitory concentration: 4670 nM
For compound 3 the middle estimate is 2.3-fold (0.37 log units) below the measured one; low and high end bracket the measured number.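

Within the data shown here, compound 2 carries no number in this assay, so no step to compound 3 can be read from this result. The compounds shown leave open whether nitro in place of cyano on this core shifts the read-out in either direction or leaves it within the scatter. No measurement here bears on the value of compound 3.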